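This account rests on a few compounds, and the source may have more. Where it says the series, first, only, none or still open, it means among the compounds named here.

Series notes. Compound 1 `COc1ccc(-c2cc(/C=C/C(=O)c3ccc(N)cc3)[nH]n2)cc1` and compound 3 `COc1ccc(-c2cc(/C=C/C(=O)c3ccc(N)cc3)[nH]n2)cc1OC` share one core, while compound 2 `COc1ccc(C(=O)/C=C/c2cc(-c3cc(OC)c(OC)c(OC)c3)n[nH]2)cc1OC` is built on another; the difference between the two cores is not broken down here. Compound 4 `COc1cc(C(=O)/C=C/c2cc(-c3cc(OC)c(OC)c(OC)c3)n[nH]2)cc(OC)c1OC` is the member that has not yet been measured.

In a functional assay on SK-MEL-5 cells (Homo sapiens) for inhibition, read by sulforhodamine B assay, with a stated time of 48 h (a lower number here means that less compound is tolerated, a higher number that more compound is tolerated), compound 1 gives 30400 nM. In this assay compound 3 gives 36100 nM. The change between them is methoxy in place of hydrogen on an aromatic carbon and the step it made is a 1.2-fold higher number from compound 1 to compound 3 (0.07 log units; within the scatter). In this assay compound 2 gives 5590 nM, the lowest of the three numbers; its gaps to compound 1 and to compound 3 both lie beyond the scatter.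

Compound 4 differs from compound 2 by methoxy in place of hydrogen on an aromatic carbon. For the measured compounds named here, this is the same kind of change as the one from compound 1 to compound 3, not the same: around the place, the carbon in compound 4 is ortho to a methoxy group, meta to a large group and also meta to a methoxy group, whereas for compound 3 the place is ortho to a methoxy group and meta to a large group only.

The expectation rests on the step of a 1.2-fold higher number from compound 1 to compound 3 (0.07 log units; within the scatter), which lies within the scatter, so little movement is expected here either. The expected step is a 1.3-fold higher number from compound 2 to compound 4 (0.10 log units; within the scatter). Compound 4 is therefore estimated to give 7000 nM in this assay. For compound 4 the estimate is expected to span 2500 nM to 20000 nM.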

Compound 4, concentration lethal to 50% of the cells: 5490 nM
Estimate against measurement, compound 4: 1.3-fold (0.11 log units) above; the range from low to high includes it.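

In this assay, for the compounds shown here, methoxy in place of hydrogen on an aromatic carbon again gives no step that can be told from the scatter, a 1.0-fold lower number from compound 2 to compound 4 (0.01 log units; within the scatter), and the two cores agree on this change: the same change on two cores in this assay, a 1.2-fold higher number (0.07 log units; within the scatter) from compound 1 to compound 3 and a 1.0-fold lower number (0.01 log units; within the scatter) from compound 2 to compound 4, 1.2-fold (0.08 log units) apart, within the scatter of two such steps. For these two pairs, then, the result from the core of compound 1 carries over to the core of compound 2, even though the carbon in compound 4 has one more methoxy group around it, meta to that carbon, than the carbon in compound 3. Going by these compounds alone, this agreement rests on only two pairs and on two steps that are both within the scatter, so it shows that the change is silent on these cores but not that a step of real size would carry from one core to the other, nor that the same would hold on any further core.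

The compounds shown carry only hydrogen or methoxy at the changed carbon, so it remains open whether a hydroxy group, a fluorine, an ethoxy group or a carboxylic acid there would give a step beyond the scatter. Going by these compounds, it also remains open whether the silence of the methoxy change extends to any read-out other than this assay.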